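A few compounds are considered here, and "the series" means these few. Any claim that something is new, unique, unknown or untested is made for them only; others in the source may bear on it.

Compound 1 `CS(=O)(=O)Nc1ccc(-c2nc3ccccc3o2)cc1`: in an assay on cells for inhibition of HSP60/HSP10 (Homo sapiens), with a stated time of 60 min (a higher number here means a weaker inhibitor, a lower number a stronger inhibitor), compound 1 gives > 100000 nM, which is a limit of the assay.
Compound 2 `COc1ccc(Cl)cc1S(=O)(=O)Nc1ccc(-c2nc3ccccc3o2)cc1`: in this assay compound 2 gives > 100000 nM, again a limit of the assay.

Both measured compounds share one core and differ only in the group on the sulfonyl sulfur. Because both sit at the limit of > 100000 nM in this assay, at which 2 of the 2 values shown sit, the step that the two limits leave unreadable from compound 1 to compound 2 cannot be read in size or direction; all that the two numbers show is that neither compound reaches a measurable strength in this assay. Compound 2 therefore stands at the edge of what the assay can report, with no numeric value behind it.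

Compound 3 `O=S(=O)(Nc1ccc(-c2nc3ccccc3o2)cc1)c1ccc(Cl)c(Cl)c1` is the next member of the series. It differs from compound 2 by 3,4-dichlorophenyl in place of 5-chloro-2-methoxyphenyl on a sulfonyl sulfur. Among the measured compounds shown here, no measured step bears on such a change, since the one step available is itself unreadable. With nothing pointing to a gain, the expectation for compound 3 in this assay is a step that the limit leaves unreadable from compound 2 to compound 3 of no readable size, most likely another limit. On that basis compound 3 is estimated at 150000 nM, with a range from 30000 nM to 1000000 nM.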

Compound 3, half-maximal inhibitory concentration: 25000 nM
Compound 3: middle estimate off by 6.0-fold (0.78 log units), on the high side; measured number below the stated range.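

Among the compounds shown here, compound 3 is the first to give a real number in this assay, at 25000 nM, so the group on the sulfonyl sulfur can move the read-out. Placing 3,4-dichlorophenyl there in place of 5-chloro-2-methoxyphenyl gives an at least 4.0-fold lower number from compound 2 to compound 3 (0.60 log units; beyond the scatter), and placing it there in place of methyl gives an at least 4.0-fold lower number from compound 1 to compound 3 (0.60 log units; beyond the scatter). Compound 2 also carries a six-membered aromatic ring on the sulfur, so such a ring alone does not bring a measurable number, and both step sizes are only minimums because the starting compounds stand at a limit: the limit of > 100000 nM in this assay, at which 2 of the 3 values shown sit.

The change from compound 2 to compound 3 removes the methoxy group and alters the chlorine substitution in a single step, so the compounds shown cannot say which of these matters, or whether both do. Going by these compounds, it also remains open how this position would respond to a phenyl ring without chlorine, or to a trifluoromethyl group, a nitrile or a carboxylic acid on that ring in place of the chlorines.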